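Trimming the ether chain of compound 1 by one carbon

The source may hold more compounds than are shown below. What is called first, only, known or untested is meant among the compounds shown, and "the series" means these compounds.

The series shares one core and varies only the group bound to the oxygen on the aromatic ring. In a functional assay on J774.A1 cells (Mus musculus) for inhibition, read by immunoassay, with a stated time of 12 h, tested at 30 uM (on this read-out lower numbers stand for less inhibition and higher numbers for more inhibition at the one concentration tested (going by the name of the read-out)), compound 1 `CC(C)CCOc1ccccc1C1CC(=O)c2ccccc2O1` gives 43.6%, which places it second highest of the three numbers measured. Compound 2 `CC(C)c1ccc(COc2ccccc2C2CC(=O)c3ccccc3O2)cc1` gives 91.7%, and compound 3 `CC(C)=CCOc1ccccc1C1CC(=O)c2ccccc2O1` gives 40.3%. The step of a number 48.1 percentage points higher from compound 1 to compound 2 (beyond the scatter) shows that the aryl group moves the read-out strongly, whereas the step of a number 3.3 percentage points lower from compound 1 to compound 3 (within the scatter) shows that a small change within the short chain leaves the number essentially where it was.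

Compound 4 `CCCCOc1ccccc1C1CC(=O)c2ccccc2O1` differs from compound 1 by hydrogen in place of methyl on a saturated chain carbon bound to two saturated chain carbons. The chain stays a plain saturated chain of the same kind, so the step of a number 3.3 percentage points lower from compound 1 to compound 3 (within the scatter) is the one that bears on it, and it was within the scatter. The large step of a number 48.1 percentage points higher from compound 1 to compound 2 (beyond the scatter) does not apply, since no aromatic group enters. Compound 4 is therefore expected to sit close to compound 1, with at most a small downward shift, as the estimated step of a number 3.6 percentage points lower from compound 1 to compound 4 (within the scatter) expresses. In this assay compound 4 is estimated at 40%, within a range from 25% to 55%.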

Compound 4, a percentage reported as inhibition, at one concentration (the size of the read-out at that concentration, not a potency): 42.5%
For compound 4 the middle estimate is 2.5 percentage points below the measured one; measured number inside the range.
By their numbers in this assay, from the lowest: compounds 3, 4 and 1 (each within the scatter of the next); then compound 2.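

In this assay, the methyl on a saturated chain carbon bound to two saturated chain carbons can be replaced by hydrogen, turning isopentyl into butyl, with a number a number 1.1 percentage points lower from compound 1 to compound 4 (within the scatter) and so no readable effect from this branch on the saturated chain. Compound 4 also adds an unbranched, saturated chain to the comparison, and the result a number 2.2 percentage points higher from compound 3 to compound 4 (within the scatter) leaves it indistinguishable from the unsaturated, branched chain, so compounds 1, 3 and 4 cannot be ranked, while the result a number 49.2 percentage points lower from compound 2 to compound 4 (beyond the scatter) shows that the large gap to the 4-isopropylphenyl group also holds against the unbranched chain. The data offer no explanation for why these short chains read alike.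

The compounds shown leave open whether a longer chain, such as octyl, would stay with the short chains or move towards compound 2. They also leave open whether an unsubstituted phenyl in place of 4-isopropylphenyl would keep the high number, and how an amine or a carboxylic acid at the end of the chain would read.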